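The source may hold more compounds than are shown below. What is called first, only, known or untested is meant among the compounds shown, and "the series" means these compounds.

Among the measured compounds shown here, compound 3 `CCCCCNc1nc(SCC)nc2ncccc12` stands second highest of the three numbers so far in a functional assay on T-24 cells (Homo sapiens) for cytotoxicity, read by neutral red uptake, with a stated time of 72 h; a higher number here means a weaker inhibitor, a lower number a stronger inhibitor. Its nearest neighbour is compound 1 `c1ccc(CCCNc2nc(NCCCc3ccccc3)c3ccccc3n2)cc1`, which in this assay gives 3450 nM, a gap within the scatter of compound 3 at 4300 nM. The furthest is compound 2 `CCNc1nc(SCC)nc2ncccc12`, which in this assay gives 20100 nM.

The step to compound 4 `CCCCCCCNc1nc(SCC)nc2ncccc12` is ethyl in place of hydrogen on a saturated chain carbon, five bonds along the chain from a nitrogen on an aromatic ring. For the measured compounds named here, only one measured step bears on it: a 4.7-fold lower number from compound 2 to compound 3 (0.67 log units; beyond the scatter), the same kind of lengthening of the same chain on the same core, at a shorter chain length. Compound 1, whose chain ends in a ring, sits close to compound 3 and offers no direction of its own.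

Because of a 4.7-fold lower number from compound 2 to compound 3 (0.67 log units; beyond the scatter) a further, smaller lowering of the number in this assay is expected for compound 4, though whether the trend continues or flattens is not shown by the data. The expected step is a 2.0-fold lower number from compound 3 to compound 4 (0.29 log units; within the scatter). Compound 4 is therefore estimated at 2200 nM, within a range from 900 nM to 6000 nM.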

Compound 4, half-maximal inhibitory concentration: 5300 nM
Beside the measured number, compound 4's estimate is 2.4-fold (0.38 log units) below it; the measured number falls inside the stated range.
By their numbers in this assay, from the lowest: compounds 1, 3 and 4 (each within the scatter of the next); then compound 2.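

In this assay the ethyl in place of hydrogen on a saturated chain carbon, five bonds along the chain from a nitrogen on an aromatic ring, gives a 1.2-fold higher number from compound 3 to compound 4 (0.09 log units; within the scatter) and so brings no change that can be told from the scatter. The lowering seen at the shorter chain therefore does not carry on at this position, although the pentyl in place of hydrogen, two bonds along the chain from a nitrogen on an aromatic ring, still gives a 3.8-fold lower number from compound 2 to compound 4 (0.58 log units; beyond the scatter) in the same assay. The series thus shows a drop that is not extended by this further lengthening.

As far as these compounds go, whether a longer chain, or a chain carrying an amine or a hydroxyl, would move the number away from that of compound 4 stays open. No supporting evidence on this result is available here.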